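Methyl for Chloro on the Hydroxyphenyl Ring

A few compounds are considered here, and "the series" means these few. Any claim that something is new, unique, unknown or untested is made for them only; others in the source may bear on it.

compound 1 `Cc1nc(C)c(-c2nn(-c3ccc(F)cc3)cc2/C=C/C(=O)c2cc(Br)ccc2O)s1` — > 250 ug/mL
compound 2 `Cc1nc(C)c(-c2nn(-c3ccc(F)cc3)cc2/C=C/C(=O)c2cc(Cl)ccc2O)s1` — > 250 ug/mL

In an ADME assay on A549 cells (Homo sapiens) for inhibition, read by MTT assay (on this read-out lower numbers stand for stronger inhibition of growth and higher numbers for weaker inhibition of growth), compound 1 gives > 250 ug/mL, which is a limit of the assay. In this assay compound 2 gives > 250 ug/mL, again a limit. Thus compound 2 stands at the limit of > 250 ug/mL in this assay, at which 2 of the 2 values shown sit, and the step that the two limits leave unreadable from compound 1 to compound 2 cannot be sized. Compound 3 `Cc1ccc(O)c(C(=O)/C=C/c2cn(-c3ccc(F)cc3)nc2-c2sc(C)nc2C)c1` differs by methyl in place of chloro on an aromatic carbon. For the measured compounds named here, the only measured step that bears on this change is unreadable, so no step beyond the scatter is expected in this assay. Compound 3 is therefore expected to sit at about 300 ug/mL, between 120 ug/mL and 1000 ug/mL, an estimated step that the limit leaves unreadable from compound 2 to compound 3.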

Compound 3, concentration for 50% growth inhibition: 47.8 ug/mL
Compound 3: middle estimate off by 6.3-fold (0.80 log units), on the high side; the measured number lies below the stated range.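

In this assay, the place para to the hydroxy group turns out to respond to its substituent: methyl in place of chloro gives an at least 5.2-fold lower number from compound 2 to compound 3 (0.71 log units; beyond the scatter), and methyl in place of bromo gives an at least 5.2-fold lower number from compound 1 to compound 3 (0.71 log units; beyond the scatter). The step between compound 1 and compound 2 cannot be read. Both of these compounds stay at a limit of the assay, so the methyl steps have no upper size: the limit of > 250 ug/mL in this assay, at which 2 of the 3 values shown sit.

On these data alone, whether an ethyl, a methoxy or an amine at this place would lower the number further remains open. So does whether plain hydrogen there would give a readable number at all.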